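A few compounds are considered here, and "the series" means these few. Any claim that something is new, unique, unknown or untested is made for them only; others in the source may bear on it.

Measured so far in the series:
Compound 1, `CC(C)N(Cc1cccc(OCCCCCC(=O)O)c1)C(=O)c1ccc(-c2ccncc2)cc1`. In an ADME assay on Raji cells (Homo sapiens) for cytotoxicity, read by CellTiter-Glo and resazurin assay, with a stated time of 72 h (a higher number here means that more compound is needed for the effect, a lower number that less compound is needed), compound 1 gives only a limit of the assay, > 26000 nM.
Compound 2, `CC(C)N(Cc1cccc(OCCCCCC(=O)O)c1)C(=O)c1ccc(-c2cccc(F)c2)cc1`. In this assay compound 2 likewise stops at a limit, > 26000 nM.
Compound 3, `CCOC(=O)CCCCCOc1cccc(CN(C(=O)c2ccc(-c3ccncc3)cc2)C(C)C)c1`. In this assay compound 3 also returns a limit, > 26000 nM.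

Compound 3 therefore stands at the same point as everything else measured here: the limit of > 26000 nM in this assay, at which 3 of the 3 values shown sit. Among the compounds with values here, no compound in the set has a readable number, so the two measured steps carry no size. The step that the two limits leave unreadable from compound 1 to compound 2 and the step that the two limits leave unreadable from compound 1 to compound 3 are both unreadable, since each joins two limits.

Compound 4 is `CCOC(=O)CCCCCOc1cccc(CN(C(=O)c2ccc(-c3ccco3)cc2)C(C)C)c1`. Relative to compound 3 the change is furan-2-yl in place of pyridin-4-yl on an aromatic carbon. Within the data shown here, no measured step exchanges pyridin-4-yl for furan-2-yl, so nothing in the data speaks directly to it; the two steps that exist are both unreadable and cannot be used to size it. With every measured value at the limit, the expectation for compound 4 is that it again reaches only a limit in this assay, so the step that the limit leaves unreadable from compound 3 to compound 4 is expected to be unreadable rather than a change beyond the scatter. The estimate for compound 4 is 35000 nM, with a range from 15000 nM to 80000 nM.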

Compound 4, half-maximal effective concentration: > 26000 nM
Compound 4 was reported as a limit (the forecaster's own chance of this, stated with the estimate: 85%); the middle value lies beyond the limit too.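

Compound 4 gives only a limit in this assay, > 26000 nM, and compound 3 also gives only a limit, so no step can be read between compound 3 and compound 4. The series stays at a single point: the limit of > 26000 nM in this assay, at which 4 of the 4 values shown sit.

The compounds shown leave open whether furan-2-yl and pyridin-4-yl differ at all in this assay.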